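A Second Nitro Group Added to Compound 3

The source may hold more compounds than are shown below. What is called first, only, known or untested is meant among the compounds shown, and "the series" means these compounds.

Of the compounds shown here, three sharing one core have been measured in a functional assay on SSMC-7721 cells (Homo sapiens) for antiproliferative activity, read by CCK-8 assay, with a stated time of 48 h; on this read-out lower numbers stand for stronger inhibition and higher numbers for weaker inhibition. Compound 1 `O=c1c2ccccc2[se]n1-c1nnc(-c2ccccc2Cl)s1` gives 40200 nM, compound 2 `Cc1ccc(-c2nnc(-n3[se]c4ccccc4c3=O)s2)cc1` gives 16600 nM, and compound 3 `O=c1c2ccccc2[se]n1-c1nnc(-c2cccc([N+](=O)[O-])c2)s1` gives 27300 nM. Compound 3 stands second highest of the three: its gap to compound 1 lies within the scatter, and so does its gap to compound 2, so no order among them can be claimed. Among the compounds with values here, the only single-point step is a 2.4-fold lower number from compound 1 to compound 2 (0.38 log units; beyond the scatter), which exchanges one substituted phenyl for another.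

Compound 4 `O=c1c2ccccc2[se]n1-c1nnc(-c2cc([N+](=O)[O-])cc([N+](=O)[O-])c2)s1` is the next compound and differs from compound 3 by nitro in place of hydrogen on an aromatic carbon, the new group entering on an aromatic carbon of a six-membered aromatic ring of carbon only, meta to a large group and meta to a nitro group. Within the data shown here, no measured step bears directly on this change, since the step from compound 1 to compound 2 concerns a different pair of groups, and the numbers of compound 1 and compound 3 lie within the scatter of each other. The expectation is therefore no step beyond the scatter in this assay, with the result for compound 4 estimated near that of compound 3, as a 1.0-fold lower number from compound 3 to compound 4 (0.00 log units; within the scatter). Compound 4 is expected to give about 27000 nM, in the range from 9000 nM to 80000 nM.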

Compound 4, half-maximal inhibitory concentration: 21600 nM
Compound 4: the middle estimate sits 1.3-fold (0.10 log units) above what was measured; the range from low to high includes it.
By their numbers in this assay, from the lowest: compounds 2, 4, 3 and 1 (each within the scatter of the next, the first and the last beyond it).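

In this assay, adding the second nitro group gives a 1.3-fold lower number from compound 3 to compound 4 (0.10 log units; within the scatter), so this addition of 3 heavy atoms and 2 hydrogen-bond acceptors, with no net charge, does not separate the pair. Within the data shown here, the earlier single-place step exchanged one substituted phenyl for another, whereas this one is the first to add a group to a phenyl ring that already carries a substituent, on an aromatic carbon meta to a large group and meta to a nitro group. Nothing in the data shown accounts for this outcome.

The compounds shown leave open whether an amine, a carboxylic acid or a methoxy group on this same carbon would also stay within the scatter or would instead produce a step as clear as a 2.4-fold lower number from compound 1 to compound 2 (0.38 log units; beyond the scatter). They also leave open whether a nitro group at this position would give a similar result on a phenyl ring without the first nitro group, and whether the small size of this step would hold on any other cell line.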